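A few compounds are considered here, and "the series" means these few. Any claim that something is new, unique, unknown or untested is made for them only; others in the source may bear on it.

Compound 1 `Cc1c(C#N)c(-c2ccccc2)nn1CCCN1CCN(c2ccc(F)cc2)CC1`: 28%
Compound 2 `COc1cccc(N2CCN(CCCn3nc(-c4ccccc4)c(C#N)c3C)CC2)c1`: 21%

In a functional assay on the whole organism (Abdomen, strain Swiss) for inhibition, with Mus musculus as the target, with stated times of 30 min, 10 min and 5 min, at a dose of 20 mg/kg by the oral route (a higher number here means a stronger effect of the compound at the dose given, a lower number a weaker effect), compound 1 gives 28%, and compound 2 gives 21%. The two numbers sit within the scatter of each other, so compound 2 stands on a level with compound 1 rather than apart from it. Within the data shown here, the only measured step, a number 7 percentage points lower from compound 1 to compound 2 (within the scatter), already swaps the group on an amine nitrogen in a ring, and it did not move the read-out beyond the scatter.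

Compound 3 `Cc1ccc(N2CCN(CCCn3nc(-c4ccccc4)c(C#N)c3C)CC2)cc1` is the next compound. It differs from compound 2 in one place: 4-methylphenyl in place of 3-methoxyphenyl on an amine nitrogen in a ring. Among the measured compounds shown here, this again changes only the group on that ring nitrogen, so the step from compound 1 to compound 2 is the one measured step that bears on it, and it was small. On that basis the step of a number 3 percentage points higher from compound 2 to compound 3 (within the scatter) is expected to stay within the scatter. Compound 3 is therefore estimated at 24% in this assay, with a likely range from 8% to 40%.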

Compound 3, a percentage reported as inhibition, in the whole organism at one dose (the size of the read-out at that dose, not a potency): 8%
The estimate for compound 3 lay 16 percentage points above the measured number, within the range that was stated.
By their numbers in this assay, from the lowest: compound 3; then compounds 2 and 1 (each within the scatter of the next).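

The group on this ring nitrogen can move the read-out after all: in this assay, 4-methylphenyl in place of 3-methoxyphenyl gives a number 13 percentage points lower from compound 2 to compound 3 (beyond the scatter) and so takes the number beyond the scatter. The change can also be confined to one substituent on the aromatic ring, since methyl in place of fluoro on an aromatic carbon gives a number 20 percentage points lower from compound 1 to compound 3 (beyond the scatter) while the rest of the molecule stays the same. Nothing measured here accounts for either drop.

Going by these compounds, it remains open whether the lower number follows the methyl group itself or its place on the aromatic ring, and how a plain phenyl, a 4-chlorophenyl or a pyridyl group on that nitrogen would read. On these data alone, what a longer chain between the shared core and the six-membered ring would do also remains open.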